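The compounds below may be only part of what the source reports. "The series", "measured", "known", "first", "only" and "open" are said of these compounds alone.

Working notes on the series. In a functional assay on MGC-803 cells (Homo sapiens) for inhibition, read by sulforhodamine B assay (a lower number here means a stronger inhibitor, a higher number a weaker inhibitor), compound 1 `CCc1ccc(NC2=CC(=O)c3nc4n(c3C2=O)[C@H]2OC[C@@H](O)[C@H]2OC4)cc1` gives 1290 nM. Compound 2 `O=C1C(Nc2ccc(C(F)(F)F)cc2)=CC(=O)c2c1nc1n2[C@H]2OC[C@@H](O)[C@H]2OC1` gives 1860 nM. For the measured compounds named here, these are the only two numbers in the set, and they lie within the scatter of each other, so they carry no order. Compound 3 `O=C1C(N2CCC2)=CC(=O)c2c1nc1n2[C@H]2OC[C@@H](O)[C@H]2OC1` gives > 16000 nM. That entry is a limit of the assay and not a number. Going by the values given here, compound 1 therefore stands within the scatter of compound 2, and its only other comparison is with a limit.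

The compound still to be measured is compound 4 `COc1ccc(NC2=CC(=O)c3nc4n(c3C2=O)[C@H]2OC[C@@H](O)[C@H]2OC4)cc1`. It carries methoxy in place of ethyl on an aromatic carbon, para to a large group, and the rest of the core of compound 1 stays as it is (methoxy in place of ethyl on an aromatic carbon). Among the compounds with values here, no measured pair isolates this change, so the expectation has no direct precedent. In this assay, no step beyond the scatter is expected, in either direction. That expectation rests on compound 2 at 1860 nM sitting within the scatter of compound 1 at 1290 nM. The estimated step of a 1.1-fold higher number from compound 1 to compound 4 (0.04 log units; within the scatter) is expected to stay within the scatter. For compound 4 the expected value is 1400 nM, with an estimated range from 600 nM to 3500 nM.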

Compound 4, half-maximal inhibitory concentration: 1680 nM
Compound 4: middle estimate off by 1.2-fold (0.08 log units), on the low side; the measured number falls inside the stated range.
By their numbers in this assay, from the lowest: compounds 1, 4 and 2 (each within the scatter of the next). At a limit, above all of these: compound 3.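

In this assay, for the compounds shown here, this is the first pair that isolates a single change at this position, and a 1.3-fold higher number from compound 1 to compound 4 (0.11 log units; within the scatter) shows that methoxy in place of ethyl on an aromatic carbon, para to a large group, moves the number by no more than the scatter. The step exchanges a carbon for an oxygen and adds one hydrogen-bond acceptor to the count, yet it gives no readable change, and the values of compounds 1, 4 and 2 now form one band, each within the scatter of the next, so this position has so far tolerated all three of its substituents without a readable difference. No measurement given here bears on why this step is so small.

From the compounds shown here alone, whether a primary amine, a carboxylic acid or a longer chain such as n-butyl in the same place would produce a step beyond the scatter stays open. Compound 3 gives > 16000 nM, which is a limit of the assay and not a number, so steps to it cannot be read.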